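From compound 2 to compound 4: expecting little change

The source may report more compounds than this note shows. Statements on the series, on what has been measured and on what is new or still open speak of the compounds shown alone.

In an ADME assay on L02 cells (Homo sapiens) for cytotoxicity, read by MTT assay, with a stated time of 72 h (a lower number here means a stronger inhibitor, a higher number a weaker inhibitor), compound 2 (`O=C(O)CCCC(=O)OCCCOc1no[n+]([O-])c1S(=O)(=O)c1ccccc1`) gives 35000 nM and sits within the scatter of the two other measured compounds. Compound 1 (`O=C(O)CCC(=O)OCCCOc1no[n+]([O-])c1S(=O)(=O)c1ccccc1`) reads 29000 nM while compound 3 (`O=C(O)c1ccccc1C(=O)OCCOc1no[n+]([O-])c1S(=O)(=O)c1ccccc1`) reads 37000 nM with no gap beyond that scatter.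

Going from compound 2 to compound 4 (`O=C(O)c1ccccc1C(=O)OCCCOc1no[n+]([O-])c1S(=O)(=O)c1ccccc1`) means one structural change (2-carboxyphenyl in place of 3-carboxypropyl on a carbonyl carbon), with 2-carboxyphenyl in place of 3-carboxypropyl on a carbonyl carbon. Within the data shown here, the only measured step nearby is a 1.2-fold higher number from compound 1 to compound 2 (0.08 log units; within the scatter) and it alters a saturated chain alone, so it bears on this swap only loosely. Compound 3 already carries 2-carboxyphenyl on a carbonyl carbon, though with a different chain leading to the core, and its value of 37000 nM lies within the scatter of compound 2.

No step beyond the scatter is therefore expected in this assay and the estimated size is a 1.0-fold higher number from compound 2 to compound 4 (0.01 log units; within the scatter) with no clear direction. Compound 4 is estimated at 36000 nM with an expected range of 20000 nM to 62000 nM for repeat measurements.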

Compound 4, half-maximal inhibitory concentration: 40000 nM
Compound 4: the middle estimate sits 1.1-fold (0.05 log units) below what was measured; low and high end bracket the measured number.
By their numbers in this assay, from the lowest: compounds 1, 2, 3 and 4 (each within the scatter of the next).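

In this assay the step of a 1.1-fold higher number from compound 2 to compound 4 (0.06 log units; within the scatter) and the step of a 1.4-fold higher number from compound 1 to compound 4 (0.14 log units; within the scatter) both put 2-carboxyphenyl on the carbonyl carbon, in place of 3-carboxypropyl and 2-carboxyethyl. Among these compounds, the earlier step changed a saturated chain alone, so these are the first readings, with the chain to the core held the same, of a six-membered aromatic ring of carbon only at this place, and neither step goes beyond the usual scatter. Nothing measured here explains why the swap leaves the reading where it is.

Every compound shown carries a carboxylic acid on the group at this carbonyl carbon, so it remains open how a plain phenyl ring without that acid would read. On these data alone, it also remains open whether an amine or an amide in place of the acid would shift the number beyond the scatter.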